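This account rests on a few compounds, and the source may have more. Where it says the series, first, only, none or still open, it means among the compounds named here.

In a functional assay on PC-3 cells (Homo sapiens) for inhibition, read by MTT assay, with a stated time of 72 h (a lower number here means a stronger inhibitor, a higher number a weaker inhibitor), compound 3 `C=CC(=O)Nc1cccc(NC(=O)CSc2nc(Nc3cccc(F)c3)c3ccccc3n2)c1` gives 5370 nM. Compound 1 `C=CC(=O)Nc1cccc(NC(=O)CSc2nc(Nc3ccccc3F)c3ccccc3n2)c1` gives 9340 nM and compound 2 `C=CC(=O)Nc1cccc(NC(=O)CSc2nc(Nc3ccccc3Cl)c3ccccc3n2)c1` gives 14400 nM. The step of a 1.7-fold lower number from compound 1 to compound 3 (0.24 log units; within the scatter) leaves compound 3 and compound 1 unseparated, whereas the step of a 2.7-fold lower number from compound 2 to compound 3 (0.43 log units; beyond the scatter) sets compound 3 apart from compound 2. Compound 4 `C=CC(=O)Nc1cccc(NC(=O)CSc2nc(Nc3cccc([N+](=O)[O-])c3)c3ccccc3n2)c1` differs from compound 3 by nitro in place of fluoro on an aromatic carbon. Among the measured compounds shown here, no measured step exchanges a fluoro for a nitro; the only substituent swap on that ring, a 1.5-fold higher number from compound 1 to compound 2 (0.19 log units; within the scatter), stayed within the scatter, and the remaining steps concern where the fluoro sits. The expectation for compound 4 is therefore a step of a 1.0-fold higher number from compound 3 to compound 4 (0.01 log units; within the scatter), most likely not beyond the scatter. Compound 4 is estimated at 5500 nM, within 1800 nM to 17000 nM.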

Compound 4, half-maximal inhibitory concentration: 46300 nM
Estimate against measurement, compound 4: 8.4-fold (0.93 log units) below, and the stated range ends below it.
By their numbers in this assay, from the lowest: compounds 3, 1 and 2 (each within the scatter of the next, the first and the last beyond it); then compound 4.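

In this assay this position on the ring proves far from indifferent to its substituent: nitro in place of fluoro gives an 8.6-fold higher number from compound 3 to compound 4 (0.94 log units; beyond the scatter) and is the largest step seen so far. The 3-nitrophenyl compound also stands apart from both earlier analogues, with a 5.0-fold higher number from compound 1 to compound 4 (0.70 log units; beyond the scatter) and a 3.2-fold higher number from compound 2 to compound 4 (0.51 log units; beyond the scatter) as the other two steps, all running the same way. No evidence at hand bears on the reason for this. Open, from the compounds shown here alone, is whether an amine or a methoxy group in that place would give a number near compound 3 or near compound 4.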